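Swapping one side group on a shared core

A few compounds are considered here, and "the series" means these few. Any claim that something is new, unique, unknown or untested is made for them only; others in the source may bear on it.

Within the data shown here, compound 2 (`CC(C)=CC[C@@H](OC[C@H](C)O)C1=CC(=O)c2c(O)ccc(O)c2C1=O`) gives 24500 nM in a functional assay on DU-145 cells (Homo sapiens) for cytotoxicity, read by MTT assay (a lower number here means a stronger inhibitor, a higher number a weaker inhibitor), and so holds the lower of the two numbers measured so far, with compound 1 (`CC(C)=CC[C@@H](OC(=O)CCO)C1=CC(=O)c2c(O)ccc(O)c2C1=O`) at 55300 nM on the higher side. Compound 3 (`CC(C)=CC[C@@H](OC(=O)c1ccco1)C1=CC(=O)c2c(O)ccc(O)c2C1=O`) changes the same spot on the shared core: (furan-2-yl)carbonyl in place of 2-hydroxypropyl on an oxygen on a saturated carbon. Among the measured compounds shown here, only one measured step bears on this, a 2.3-fold lower number from compound 1 to compound 2 (0.35 log units; beyond the scatter) when (2-hydroxyethyl)carbonyl gave way to 2-hydroxypropyl, a modest change. For the measured compounds named here, compound 3 puts a carbonyl back on that oxygen, which hints at a partial reversal toward a higher number, but no measured compound carries its furan ring. So in this assay no step beyond the scatter is expected (the estimate is a 1.1-fold higher number from compound 2 to compound 3 (0.06 log units; within the scatter)). For compound 3 the estimated value is 28000 nM (expected range 9000 nM to 70000 nM).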

Compound 3, half-maximal inhibitory concentration: > 100000 nM
Compound 3: a limit, no number; the forecaster's own chance of this, stated with the estimate: 10%; middle value at least 3.5-fold (0.55 log units) from the limit.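

Compound 3 gives > 100000 nM in this assay, which is a limit of the assay and not a number. Replacing 2-hydroxypropyl with (furan-2-yl)carbonyl on this oxygen brings an at least 4.0-fold higher number from compound 2 to compound 3 (0.61 log units; beyond the scatter), so this position responds to a larger change than the first step revealed, and the response here is a loss. Between the two compounds with a carbonyl on this oxygen, furan-2-yl in place of 2-hydroxyethyl gives an at least 1.8-fold higher number from compound 1 to compound 3 (0.25 log units; that floor lies within the scatter), so this comparison alone shows no real loss.

As far as these compounds go, how far compound 3 truly lies from the others stays open because its reading stops at a limit: the limit of > 100000 nM in this assay, at which 1 of the 3 values shown sits. From the compounds shown here alone, it is also open whether a phenyl ring in place of the furan ring, or an amine on a longer chain, would bring the number down.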